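From anilino to 4-methylpiperazin-1-yl on the shared core

The compounds below may be only part of what the source reports. "The series", "measured", "known", "first", "only" and "open" are said of these compounds alone.

In a functional assay on HCT-116 cells (Homo sapiens) for antiproliferative activity, read by CCK-8 assay, with a stated time of 72 h (a lower number here means a stronger inhibitor, a higher number a weaker inhibitor), compound 1 (`Nc1ccccc1NC(=O)c1ccc(Cn2cnc3c(Nc4ccccc4)nc(Cl)nc32)cc1`) gives 1070 nM and sits within the scatter of both other measured compounds. Compound 2 (`CC(C)n1cnc2c(NCc3ccc(C(=O)Nc4ccccc4N)cc3)nc(Cl)nc21`) gives 800 nM in this assay and compound 3 (`Nc1ccccc1NC(=O)c1ccc(COCNc2nc(Nc3ccccc3)c3ncn(C4CCCC4)c3n2)cc1`) gives 960 nM in the same test, so the three values carry no order.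

The step under review leads from compound 1 to compound 4 (`CN1CCN(c2nc(Cl)nc3c2ncn3Cc2ccc(C(=O)Nc3ccccc3N)cc2)CC1`). It places 4-methylpiperazin-1-yl in place of anilino on an aromatic carbon. Within the data shown here, no measured pair isolates this change, and no measured compound carries 4-methylpiperazin-1-yl, so the data give no direct size for the step.

The working expectation in this assay is a step no larger than the scatter, with neither direction favoured. This rests on compound 2 at 800 nM and compound 3 at 960 nM both staying within the scatter of compound 1 although each differs from it in more than one place. That support is indirect, so the range is kept wide. The expected change is a 1.1-fold lower number from compound 1 to compound 4 (0.03 log units; within the scatter) and remains an estimate. For compound 4 the estimated value is 1000 nM with an expected range of 330 nM to 3000 nM in this assay for now.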

Compound 4, half-maximal inhibitory concentration: 310 nM
Beside the measured number, compound 4's estimate is 3.2-fold (0.51 log units) above it, and the stated range ends above it.
By their numbers in this assay, from the lowest: compound 4; then compounds 2, 3 and 1 (each within the scatter of the next).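

In this assay, among these compounds, replacing anilino with 4-methylpiperazin-1-yl on the aromatic carbon next to the ring nitrogen gives a 3.5-fold lower number from compound 1 to compound 4 (0.54 log units; beyond the scatter) and is the only step so far that isolates a single place. This shows that the number at this position responds to the group it carries, which compounds 1, 2 and 3 could not show, as they differ from one another in more than one place. The anilino group, with its six-membered aromatic ring of carbon and its hydrogen-bond donor, is therefore not required here for the activity seen on these cells, and no information at hand explains why the non-aromatic ring with two hetero atoms gives the lower number.

Still open, from the compounds shown here alone, is which feature of the entering group carries the step, since it differs from anilino in aromaticity, ring atoms and donor count all at once. Piperidin-1-yl, morpholin-4-yl or piperazin-1-yl without the methyl group at this same aromatic carbon would begin to separate these features, and a single result on one cell line leaves the generality of the step unsettled.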